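Indole for Pyridine: Expected Shift in Microsomal Clearance

A few compounds are considered here, and "the series" means these few. Any claim that something is new, unique, unknown or untested is made for them only; others in the source may bear on it.

Compound 3 `Nc1ccc(S(=O)(=O)N2CCN(c3ncc(C(O)(C(F)(F)F)C(F)(F)F)cc3-c3cccnc3)CC2)cn1` gives 17 mL.min-1.g-1 in an ADME assay (liver) for metabolic stability, with Liver microsome (Homo sapiens) as the target, using microsomes and NADPH, with a stated time of 30 min, tested at 1 uM (on this read-out lower numbers stand for slow clearance and higher numbers for fast clearance), the lowest of the two numbers seen; its nearest neighbour is compound 2 `CC(C)(C)n1cc(-c2cc(C(O)(C(F)(F)F)C(F)(F)F)cnc2N2CCN(S(=O)(=O)c3ccc(N)nc3)CC2)cn1`, which gives 86 mL.min-1.g-1, and the step of a 5.1-fold lower number from compound 2 to compound 3 (0.70 log units; beyond the scatter) lies beyond the scatter. Compound 1 `CC(C)(O)C#Cc1cc(C(O)(C(F)(F)F)C(F)(F)F)cnc1N1CCN(S(=O)(=O)c2ccc(N)nc2)CC1` sits at a limit of this assay, < 14 mL.min-1.g-1; that is the limit of < 14 mL.min-1.g-1 in this assay, at which 1 of the 3 values shown sits. The step of an at least 1.2-fold higher number from compound 1 to compound 3 (0.08 log units; that floor lies within the scatter) has a floor within the scatter. Compound 4 `Nc1ccc(S(=O)(=O)N2CCN(c3ncc(C(O)(C(F)(F)F)C(F)(F)F)cc3-c3cc4ccccc4[nH]3)CC2)cn1` differs from compound 3 by 1H-indol-2-yl in place of pyridin-3-yl on an aromatic carbon. For the measured compounds named here, the only measured step exchanging one aryl group for another on this carbon, a 5.1-fold lower number from compound 2 to compound 3 (0.70 log units; beyond the scatter), moved toward lower numbers when pyridin-3-yl entered, so the reverse direction, a modest rise, is expected here: a 2.6-fold higher number from compound 3 to compound 4 (0.42 log units; beyond the scatter). Compound 4 is therefore estimated at 45 mL.min-1.g-1, between 15 mL.min-1.g-1 and 140 mL.min-1.g-1.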

Compound 4, intrinsic clearance in microsomes: < 14 mL.min-1.g-1
Compound 4 was reported as a limit; the forecaster's own chance of this, stated with the estimate: 5%; middle value at least 3.2-fold (0.50 log units) away from the limit.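

Two aromatic rings on this carbon, as in 1H-indol-2-yl, did not bring fast clearance in this assay, and replacing 1-(tert-butyl)-1H-pyrazol-4-yl gives an at least 6.1-fold lower number from compound 2 to compound 4 (0.78 log units; beyond the scatter). Against pyridin-3-yl the result is an at least 1.2-fold lower number from compound 3 to compound 4 (0.08 log units; that floor lies within the scatter), so these two groups cannot be ordered. The value of compound 4 is a limit, and its step from compound 1, also a limit, cannot be read: the limit of < 14 mL.min-1.g-1 in this assay, at which 2 of the 4 values shown sit.

From the compounds shown here alone, how far compound 4 lies past this limit remains open. So does whether an amine or a carboxylic acid on this carbon would keep clearance as low.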